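The source may hold more compounds than are shown below. What is called first, only, known or untested is meant among the compounds shown, and "the series" means these compounds.

Working notes on the series

Two compounds have been run in a functional assay on A549 cells (Homo sapiens) for antiproliferative activity, read by MTT assay, with a stated time of 72 h (a lower number here means a stronger inhibitor, a higher number a weaker inhibitor), so far. Compound 1, `O=C1Nc2ccc(Br)cc2/C1=C1/Cc2ccccc2C1=O`, carries a bromo group on a different core from the rest. In this assay compound 1 reaches only the limit of > 100000 nM, which is a limit of the assay and not a number. Compound 2, `O=C1NC(=S)N/C1=C1\C(=O)Nc2ccccc21`, gives 45800 nM in this assay. Among the compounds with values here, compound 2 thus stands as the only compound of the pair with a measured number; the other value shown sits at the limit (the limit of > 100000 nM in this assay, at which 1 of the 2 values shown sits), so no step between measured compounds can be stated, and nothing further follows from the pair beyond what the two values show.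

The next compound, compound 3, `O=C1NC(=S)N/C1=C1\C(=O)Nc2c(Br)cccc21`, is built from compound 2 by a single change: bromo in place of hydrogen on an aromatic carbon. Within the data shown here, no measured step of this kind exists on the shared core of compound 2, so the size of the change in this assay is open. The working expectation is a step from compound 2 to compound 3 of a 1.3-fold lower number from compound 2 to compound 3 (0.12 log units; within the scatter), that is, little movement beyond the usual scatter, with no clear direction. On that basis compound 3 is expected to give about 35000 nM in this assay, with a likely range from 8000 nM to 120000 nM.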

Compound 3, half-maximal inhibitory concentration: 3800 nM
Compound 3: middle estimate off by 9.2-fold (0.96 log units), on the high side; measured number below the stated range.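

Within the data shown here, this is the first measured step on the shared core. In this assay, bromo in place of hydrogen on an aromatic carbon, ortho to a fused ring and meta to a fused ring, gives a 12-fold lower number from compound 2 to compound 3 (1.08 log units; beyond the scatter) and so shows that this position of the six-membered aromatic ring is not indifferent to substitution. Among these compounds, compound 1 also carries a bromo group, but on a different core, and its > 100000 nM is a limit of the assay and not a number, so it offers no comparison with this step. No measurement shown bears on why the number falls on this change.

Among the compounds shown here, with only one group at one position, it remains open whether the lower number belongs to bromo itself or would also appear with chloro, methoxy or an amine on the same carbon. As far as these compounds go, it also remains open whether bromo on the other carbons of this ring would move the number in the same way, and whether the step carries over to any other core.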